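The source may report more compounds than this note shows. Statements on the series, on what has been measured and on what is new or still open speak of the compounds shown alone.

Values so far in an ADME assay on microsomes from liver (Mus musculus) for metabolic stability, read by LC-MS, with a stated time of 30 min, tested at 1 uM; a higher number here means that more of the compound is left, a lower number that less of the compound is left:
- compound 1 `Cc1ccccc1S(=O)(=O)c1ccc(CNC(=O)c2cc3cnccc3[nH]2)cc1` gives 15%
- compound 2 `O=C(NCc1ccc(S(=O)(=O)c2cccc(F)c2)cc1)c1cc2cnccc2[nH]1` gives 44%
- compound 3 `O=C(NCc1ccc(S(=O)(=O)c2ccccc2)cc1)c1ccc2nccn2c1` gives 18%

Compound 2 stands highest of the three, and compound 1 and compound 3 both lie lower by more than the scatter. Next is compound 4 `O=C(NCc1ccc(S(=O)(=O)c2ccccc2C(F)(F)F)cc1)c1cc2cnccc2[nH]1`, which differs from compound 2 on a sulfonyl sulfur: 2-(trifluoromethyl)phenyl in place of 3-fluorophenyl on a sulfonyl sulfur (2-(trifluoromethyl)phenyl in place of 3-fluorophenyl). Among the compounds with values here, one measured step bears on this place, a number 29 percentage points higher from compound 1 to compound 2 (beyond the scatter) (3-fluorophenyl in place of 2-methylphenyl). Within the data shown here, compound 3 has a different core and offers no step here. Compound 4 gives up the 3-fluorophenyl group of compound 2, while the 2-methylphenyl compound 1 sits at 15% (the closest measured comparison for the entering group). Part of the measured step is therefore expected to be lost, though one step cannot show how much. The expected step is a fall, a number 14 percentage points lower from compound 2 to compound 4 (beyond the scatter) (smaller in size than the measured one). For compound 4 the estimated value is 30% (expected range 13% to 52%).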

Compound 4, percent of the compound remaining: 41%
Compound 4: the middle estimate sits 11 percentage points below what was measured; the range from low to high includes it.
By their numbers in this assay, from the lowest: compounds 1 and 3 (each within the scatter of the next); then compounds 4 and 2 (each within the scatter of the next).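

In this assay, the 2-(trifluoromethyl)phenyl and 3-fluorophenyl groups on the sulfonyl sulfur cannot be told apart: a number 3 percentage points lower from compound 2 to compound 4 (within the scatter). Trifluoromethyl in place of methyl on an aromatic carbon gives a number 26 percentage points higher from compound 1 to compound 4 (beyond the scatter), so the higher number seen earlier is not tied to the 3-fluorophenyl group alone, and among the three compounds on the shared core, compound 1 stands apart from the other two. Nothing on hand explains this difference between the methyl and trifluoromethyl groups.

As far as these compounds go, it remains open whether other groups on that aromatic carbon, such as chloro or methoxy, would sit with compound 1 or with compound 2 and compound 4. Where a plain phenyl on the shared core would fall, and how the core of compound 3 compares with that core, also remain open.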